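The source may hold more compounds than are shown below. What is called first, only, known or untested is meant among the compounds shown, and "the series" means these compounds.

Measured so far:
compound 1, `Cc1cccc(C)c1-c1cccc(COc2ccc(CCC(=O)O)cn2)c1`, giving 3.5 nM in a functional assay on CHO cells for agonist activity at Free fatty acid receptor 1 (Homo sapiens), read by calcium flux; a lower number here means that less compound is needed, a higher number that more compound is needed for the effect
compound 2, `Cc1cc(OCc2cccc(-c3c(C)cccc3C)c2)ncc1CCC(=O)O`, giving 9.3 nM in this assay

Compound 1 stands with the lowest of the two numbers; its nearest neighbour is compound 2, and the step of a 2.7-fold higher number from compound 1 to compound 2 (0.42 log units; beyond the scatter) lies beyond the scatter.

Compound 3, `Cc1cc(CCC(=O)O)cnc1OCc1cccc(-c2c(C)cccc2C)c1`, has not yet been measured. It differs from compound 1 by methyl in place of hydrogen on an aromatic carbon, the new group sitting on an aromatic carbon of a six-membered aromatic ring with 1 nitrogen, ortho to a large group, two atoms from the ring nitrogen and meta to a 2-carboxyethyl group. The same kind of change, a methyl in place of hydrogen on an aromatic carbon of the shared core, though at another carbon, has been measured once: a 2.7-fold higher number from compound 1 to compound 2 (0.42 log units; beyond the scatter). Among the compounds with values here, only this one step bears on the question, so the expectation for compound 3 is a modest rise in the number, of roughly the size seen from compound 1 to compound 2, though a change within the scatter cannot be excluded. Compound 3 is therefore expected to give 7 nM in this assay, between 2.5 nM and 20 nM, an estimated step of a 2.0-fold higher number from compound 1 to compound 3 (0.30 log units; within the scatter).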

Compound 3, half-maximal effective concentration: 2500 nM
Estimate against measurement, compound 3: 360-fold (2.55 log units) below; the measured number lies above the stated range.
By their numbers in this assay, from the lowest: compound 1; then compound 2; then compound 3.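

The step of a 710-fold higher number from compound 1 to compound 3 (2.85 log units; beyond the scatter) shows that in this assay this carbon, ortho to a large group, two atoms from the ring nitrogen and meta to a 2-carboxyethyl group, accepts a methyl far less readily than the earlier compounds could have shown. Within the data shown here, those compounds held only the step of a 2.7-fold higher number from compound 1 to compound 2 (0.42 log units; beyond the scatter) and so gave the size of this change at one carbon alone; together the two steps show that the same methyl in place of hydrogen, a single added heavy atom, can bring either a modest or a large rise in the number according to which aromatic carbon of the shared core carries it. Nothing measured here accounts for the size of the new step.

The compounds shown leave open whether a fluorine atom, a chlorine atom or a methoxy group on this same carbon would give a number close to that of compound 1 or close to that of compound 3. They also leave open what a methyl on this carbon would do in the presence of the methyl of compound 2, as no compound shown carries both.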